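Thiazole substituent series: aminomethyl replacement at the oxetane position

The source may report more compounds than this note shows. Statements on the series, on what has been measured and on what is new or still open speak of the compounds shown alone.

Measured so far:
compound 1 `C[C@@H]1CN(c2sc(C3CC3)nc2-c2nc3ccccc3[nH]2)CCN1C(=O)Cn1cnc2cccnc21` gives 994 nM in an assay on blood for inhibition of C-X-C chemokine receptor type 3 (Homo sapiens), with a stated time of 30 min; on this read-out lower numbers stand for stronger inhibition and higher numbers for weaker inhibition
compound 2 `C[C@@H]1CN(c2sc(C3COC3)nc2-c2nc3ccccc3[nH]2)CCN1C(=O)Cn1cnc2cccnc21` gives 1150 nM in this assay

Compound 2 holds the higher of the two numbers recorded, but the gap to compound 1 is small: the step of a 1.2-fold higher number from compound 1 to compound 2 (0.06 log units; within the scatter) does not rise above the scatter, so the two compounds cannot be ranked against each other on this read-out.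

Compound 3 `C[C@@H]1CN(c2sc(CN(C)C)nc2-c2nc3ccccc3[nH]2)CCN1C(=O)Cn1cnc2cccnc21` has not been measured. It differs from compound 2 as follows: (dimethylamino)methyl in place of oxetan-3-yl on an aromatic carbon. Among the measured compounds shown here, the only measured step exchanges one small ring for another at this same aromatic carbon and left the number essentially unchanged; no step in this set tells how an acyclic amine-bearing group at that carbon behaves, so no direction beyond the scatter can be inferred. Compound 3 is therefore expected to land close to compound 2, with a step of a 1.2-fold lower number from compound 2 to compound 3 (0.06 log units; within the scatter) that is itself within the scatter, and the estimate is set at 1000 nM with a range from 300 nM to 3500 nM in this assay.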

Compound 3, half-maximal inhibitory concentration: 1150 nM
The estimate for compound 3 lay 1.2-fold (0.06 log units) below the measured number; measured number inside the range.
By their numbers in this assay, from the lowest: compounds 1, 2 and 3 (each within the scatter of the next).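

Exchanging oxetan-3-yl for (dimethylamino)methyl on this aromatic carbon gives no change at the digits printed from compound 2 to compound 3 (within the scatter) in this assay, and exchanging cyclopropyl for the same group gives a 1.2-fold higher number from compound 1 to compound 3 (0.06 log units; within the scatter) on this read-out. The earlier step only swapped one small ring for another; these steps show that a group with no ring, carrying a nitrogen instead of the oxetane oxygen, also stays within the scatter, so compound 1, compound 2 and compound 3 cannot be ranked. Nothing available explains why the number stays level across these three groups.

On these data alone, it remains open whether a primary amine, a carboxylic acid or a longer chain on this carbon would move the number beyond the scatter. As far as these compounds go, whether a change elsewhere on the shared core would do so is also open.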